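Piperidine to methylpiperazine on a quinazoline antiproliferative series

The source may hold more compounds than are shown below. What is called first, only, known or untested is meant among the compounds shown, and "the series" means these compounds.

Measured compounds: compound 1 `COc1cc2ncnc(N3CCc4ccccc43)c2cc1NC(=O)/C=C/CN1CCCCC1` gives 4180 nM; compound 2 `COc1cc2ncnc(N3CCc4ccccc43)c2cc1NC(=O)/C=C/CN1CCN(C)CC1` gives 9180 nM; compound 3 `O=C(/C=C/CN1CCCCC1)Nc1cc2c(N3CCCc4ccccc43)ncnc2cc1O[C@@H]1CCOC1` gives 3630 nM. All three were tested in a functional assay on PC-3 cells (Homo sapiens) for antiproliferative activity, read by MTT assay, with a stated time of 72 h; on this read-out higher numbers stand for weaker inhibition and lower numbers for stronger inhibition.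

Compound 1 and compound 2 differ in one place (4-methylpiperazin-1-yl in place of piperidin-1-yl on a saturated chain carbon bound to a double-bonded chain carbon). This change produced a 2.2-fold higher number from compound 1 to compound 2 (0.34 log units; beyond the scatter). Compound 3 carries a different core from compound 1; the difference between the two cores is not broken down here. Compound 4 `CN1CCN(C/C=C/C(=O)Nc2cc3c(N4CCCc5ccccc54)ncnc3cc2O[C@@H]2CCOC2)CC1` has not yet been measured. It differs from compound 3 in the same way (4-methylpiperazin-1-yl in place of piperidin-1-yl on a saturated chain carbon bound to a double-bonded chain carbon), at the same place as before.

Since the earlier step from compound 1 to compound 2 was a 2.2-fold higher number from compound 1 to compound 2 (0.34 log units; beyond the scatter), a step of comparable size is expected from compound 3 to compound 4, namely a 2.2-fold higher number from compound 3 to compound 4 (0.34 log units; beyond the scatter). Compound 4 is therefore estimated at 8000 nM in this assay, between 3500 nM and 18000 nM.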

Compound 4, half-maximal inhibitory concentration: 9450 nM
Estimate against measurement, compound 4: 1.2-fold (0.07 log units) below; the range from low to high includes it.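

In this assay the same change, 4-methylpiperazin-1-yl in place of piperidin-1-yl, gave a 2.6-fold higher number from compound 3 to compound 4 (0.42 log units; beyond the scatter) and so went the same way on the second core, with no real difference in size between the two steps: the same change on two cores in this assay, a 2.2-fold higher number (0.34 log units; beyond the scatter) from compound 1 to compound 2 and a 2.6-fold higher number (0.42 log units; beyond the scatter) from compound 3 to compound 4, 1.2-fold (0.07 log units) apart, within the scatter of two such steps. This shows that the change carried over between the core of compound 1 and the core of compound 3. Within the data shown here, with only two pairs, it does not show that the change would carry to any other core, and it gives no reason for the weaker inhibition.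

The compounds shown leave open how morpholin-4-yl, dimethylamino or a piperazine without the methyl group would read on this chain. They also leave open whether a longer chain would keep the step.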